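This account rests on a few compounds, and the source may have more. Where it says the series, first, only, none or still open, it means among the compounds named here.

Of the compounds shown here, three that share one core have been measured in a functional assay on HeLa cells (Homo sapiens) for inhibition, read by MTT assay, with a stated time of 72 h; a lower number here means a stronger inhibitor, a higher number a weaker inhibitor. Compound 2 `O=C(O)/C=C/C(=O)c1ccccc1` gives 30600 nM in this assay. Compound 1 `O=C(O)/C=C/C(=O)c1ccc(Cl)c(Cl)c1` gives 28300 nM, a number that sits within the scatter of compound 2. Compound 3 `CCCCCCCCCCCCc1ccc(C(=O)/C=C/C(=O)O)cc1` gives 5820 nM, a lower number than compound 2 by a margin that lies beyond the scatter. Compound 2 thus stands at the high end of the three numbers, with compound 1 close beside it and compound 3 well away from it.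

Compound 4 `CC(C)(C)c1ccc(C(=O)/C=C/C(=O)O)cc1` has not yet been measured in this assay. Relative to compound 2 it differs in one place: tert-butyl in place of hydrogen on an aromatic carbon. The group enters on an aromatic carbon of a six-membered aromatic ring of carbon only, para to a group of 7 heavy atoms. Within the data shown here, no measured pair differs by exactly this change. The expectation rests on what the three values show: a substituted ring gives a lower number in compound 3, while compound 1 stays within the scatter of compound 2. The step from compound 2 to compound 4 is expected to be a moderate fall, a 2.0-fold lower number from compound 2 to compound 4 (0.31 log units; beyond the scatter), smaller than the gap compound 3 shows and possibly not beyond the scatter. Compound 4 is estimated at 15000 nM, within a range from 6000 nM to 35000 nM.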

Compound 4, half-maximal inhibitory concentration: 5100 nM
Estimate against measurement, compound 4: 2.9-fold (0.47 log units) above; measured number below the stated range.
By their numbers in this assay, from the lowest: compounds 4 and 3 (each within the scatter of the next); then compounds 1 and 2 (each within the scatter of the next).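

In this assay, among these compounds, tert-butyl in place of hydrogen on the aromatic carbon para to a group of 7 heavy atoms gives a 6.0-fold lower number from compound 2 to compound 4 (0.78 log units; beyond the scatter), the first step on the shared core that can be read from a pair differing in one place. It also shows that a long chain is not required for a number of this size at this position: compound 4 gives 5100 nM and compound 3, with its dodecyl chain, gives 5820 nM, two values within the scatter of each other. Nothing measured here accounts for the step, so its cause remains unknown.

The compounds shown leave open how a smaller group such as methyl would behave at this position, and whether a group carrying nitrogen or oxygen, such as an amine or a methoxy group, would give a number close to that of compound 4. They also leave open whether the step from hydrogen to tert-butyl would persist if the carboxylic acid of the shared core were replaced by its methyl ester.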